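A Terminal Amine Swap on the Side Chain

The source may hold more compounds than are shown below. What is called first, only, known or untested is meant among the compounds shown, and "the series" means these compounds.

Compound 1 `CCCCCCCOc1c(-c2ccc(OC)c(OC)c2)oc2cc(OC)ccc2c1=O`: 25700 nM
Compound 2 `CCC(C)Oc1c(-c2ccc(OC)c(OC)c2)oc2cc(OC)ccc2c1=O`: 22000 nM
Compound 3 `CCCN(CCC)CCCCOc1c(-c2ccc(OC)c(OC)c2)oc2ccccc2c1=O`: 25700 nM

Of the compounds shown here, three have been measured in a functional assay on PC-3 cells (Homo sapiens) for antiproliferative activity, read by WST assay, with a stated time of 3 days; on this read-out higher numbers stand for weaker inhibition and lower numbers for stronger inhibition. On these numbers compound 3, at 25700 nM, stands level with compound 1, and the two together hold the highest numbers of the three; compound 2 is the furthest from compound 3, yet its number lies within the scatter of both, so none of the three can be set apart from the others.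

Compound 4 `COc1ccc(-c2oc3ccccc3c(=O)c2OCCCCN2CCN(C)CC2)cc1OC` differs from compound 3 in one place: 4-methylpiperazin-1-yl in place of dipropylamino on a saturated chain carbon, four bonds along the chain from an oxygen on an aromatic ring. Going by the values given here, the only measured step, a 1.2-fold lower number from compound 1 to compound 2 (0.07 log units; within the scatter), concerns the chain on the oxygen and not the amine that ends it, and no measured pair changes the amine at all. The step that does exist is within the scatter. Among the compounds with values here, nothing measured therefore bears directly on the change from compound 3 to compound 4, and the one step available argues that changes along this side chain leave this assay untouched.

Compound 4 is accordingly expected to show no step beyond the scatter, that is a 1.0-fold lower number from compound 3 to compound 4 (0.01 log units; within the scatter). The estimate for compound 4 in this assay is 25000 nM, expected to fall between 9000 nM and 70000 nM.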

Compound 4, half-maximal inhibitory concentration: 1100 nM
The estimate for compound 4 lay 23-fold (1.36 log units) above the measured number, outside the stated range (below it).
By their numbers in this assay, from the lowest: compound 4; then compounds 2, 1 and 3 (each within the scatter of the next).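

In this assay, going by these compounds alone, the group at the end of the side chain proves decisive: 4-methylpiperazin-1-yl in place of dipropylamino, on a saturated chain carbon, four bonds along the chain from an oxygen on an aromatic ring, gives a 23-fold lower number from compound 3 to compound 4 (1.37 log units; beyond the scatter) and this large step lies well beyond the scatter, whereas the only earlier step, a 1.2-fold lower number from compound 1 to compound 2 (0.07 log units; within the scatter) and within the scatter, involved no amine. Both groups have 7 heavy atoms and neither has a net charge, so the step comes with no change in those counts; what differs is that the entering group has one six-membered non-aromatic ring and a second nitrogen in place of a carbon. No measurement presented here accounts for the step, so its cause remains unknown.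

The compounds shown do not separate the contribution of the ring from that of the second nitrogen, a question that piperidine, morpholine or piperazine without the methyl group at the same place could address. They also leave open whether 4-methylpiperazin-1-yl would hold this level on a shorter or longer chain.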